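The source may report more compounds than this note shows. Statements on the series, on what has been measured and on what is new or still open speak of the compounds shown alone.

Of the compounds shown here, three have so far been measured in an ADME assay on liver for metabolic stability, with Liver microsome (Homo sapiens) as the target, using microsomes; on this read-out lower numbers stand for slow clearance and higher numbers for fast clearance. Compound 1 `O=C(NC[C@@H]1CCCO1)c1cn(Cc2ccc(-n3cccn3)cc2)c2cccnc12` gives 133 mL/min/kg there. Compound 2 `O=C(N[C@H]1CCCC[C@@H]1O)c1cn(Cc2ccc(-c3cncnc3)cc2)c2cccnc12` gives 104 mL/min/kg in this assay, the second highest of the three numbers; its gap to compound 1 lies within the usual scatter of repeated measurements, whereas compound 3 `Cc1ccnc2c(C(=O)N[C@H]3CCOC[C@@H]3O)cn(Cc3ccc(-c4ccn(C)n4)cc3)c12`, with 10.6 mL/min/kg in this assay, sits clearly lower, beyond that scatter. Compound 4 `O=C(N[C@H]1CCCC[C@@H]1O)c1cn(Cc2ccc(-n3cc(-c4ccncc4)cn3)cc2)c2cccnc12` has not been measured yet. It differs from compound 2 in one place: 4-(pyridin-4-yl)-1H-pyrazol-1-yl in place of pyrimidin-5-yl on an aromatic carbon. Going by the values given here, no measured pair shows what such a change does here, so nothing beyond the scatter is expected in either direction, and the expected change is a 1.1-fold higher number from compound 2 to compound 4 (0.02 log units; within the scatter). In this assay compound 4 is estimated at 110 mL/min/kg, within a range from 50 mL/min/kg to 240 mL/min/kg.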

Compound 4, clearance: 140 mL/min/kg
Estimate against measurement, compound 4: 1.3-fold (0.10 log units) below; measured number inside the range.
By their numbers in this assay, from the lowest: compound 3; then compounds 2, 1 and 4 (each within the scatter of the next).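

On the aromatic carbon para to a large group, 4-(pyridin-4-yl)-1H-pyrazol-1-yl in place of pyrimidin-5-yl gives a 1.3-fold higher number from compound 2 to compound 4 (0.13 log units; within the scatter) in this assay. So at this position, a group with one more aromatic ring leaves clearance fast, with no change that can be told from the scatter. No measurement here offers any explanation for this result. The compounds shown leave open whether an amine or a carboxylic acid in this place would bring the number clearly down.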